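The compounds below may be only part of what the source reports. "The series", "measured", "known", "first", "only" and "open" are said of these compounds alone.

Working notes on the sulfonamide series. Compound 1 `O=S(=O)(NCCCCNCc1ccc(Br)cc1)c1cc(C(F)(F)F)cc(C(F)(F)F)c1` in a functional assay on A2780 cells (Homo sapiens) for inhibition, read by MTT assay, with a stated time of 72 h (on this read-out higher numbers stand for weaker inhibition of growth and lower numbers for stronger inhibition of growth), gives 2100 nM. Compound 2 `O=S(=O)(NCCCNCc1ccccc1)c1cc(C(F)(F)F)cc(C(F)(F)F)c1` gives 4900 nM, and compound 3 `O=S(=O)(NCCCNCc1ccc(Br)cc1)c1cc(C(F)(F)F)cc(C(F)(F)F)c1` gives 2600 nM. Of the three numbers compound 1 has the lowest; its nearest neighbour is compound 3, a step within the scatter, a 1.2-fold higher number from compound 1 to compound 3 (0.09 log units; within the scatter), while the furthest is compound 2, a step beyond it, a 2.3-fold higher number from compound 1 to compound 2 (0.37 log units; beyond the scatter).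

Compound 4 `COc1ccc(CNCCCNS(=O)(=O)c2cc(C(F)(F)F)cc(C(F)(F)F)c2)cc1` has not yet been measured. It differs from compound 1 in one place: (4-methoxybenzyl)amino in place of ((4-bromobenzyl)amino)methyl on a saturated chain carbon, three bonds along the chain from a sulfonamide nitrogen. Among the compounds with values here, two measured steps bear on this change. Putting (4-bromobenzyl)amino in place of ((4-bromobenzyl)amino)methyl on the chain stayed within the scatter, a 1.2-fold higher number from compound 1 to compound 3 (0.09 log units; within the scatter). Bromo in place of hydrogen on an aromatic carbon also stayed within the scatter, a 1.9-fold lower number from compound 2 to compound 3 (0.28 log units; within the scatter). Within the data shown here, no measured compound carries a methoxy group, so that part of the change is untested. The step from compound 1 to compound 4 is therefore expected to be small, most likely toward a somewhat higher number, a 1.7-fold higher number from compound 1 to compound 4 (0.22 log units; within the scatter). Compound 4 is expected to give about 3500 nM, with a range from 1500 nM to 8000 nM.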

Compound 4, concentration for 50% growth inhibition: 1700 nM
Beside the measured number, compound 4's estimate is 2.1-fold (0.31 log units) above it; the measured number falls inside the stated range.
By their numbers in this assay, from the lowest: compounds 4, 1, 3 and 2 (each within the scatter of the next, the first and the last beyond it).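

In this assay, within the data shown here, replacing hydrogen with methoxy on an aromatic carbon gives the first step on that carbon to go beyond the scatter (a 2.9-fold lower number from compound 2 to compound 4 (0.46 log units; beyond the scatter)), while bromo in place of hydrogen stayed within it (a 1.9-fold lower number from compound 2 to compound 3 (0.28 log units; within the scatter)). Methoxy in place of bromo stays within the scatter (a 1.5-fold lower number from compound 3 to compound 4 (0.18 log units; within the scatter)), as does (4-methoxybenzyl)amino in place of ((4-bromobenzyl)amino)methyl (a 1.2-fold lower number from compound 1 to compound 4 (0.09 log units; within the scatter)), so neither the methoxy and bromo groups nor these two side chains can be told apart here. No measurement on hand offers an explanation for these steps.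

On these data alone, whether a nitrile or a hydroxyl group on the same aromatic carbon would give a step of similar size remains open. Also open, as far as these compounds go, is how methoxy behaves on the longer chain of compound 1.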